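The compounds below may be only part of what the source reports. "The series", "measured", "known", "first", "only" and "open" are said of these compounds alone.

For the measured compounds named here, in a functional assay on MIA PaCa-2 cells (Homo sapiens) for antiproliferative activity, read by MTT assay, with a stated time of 72 h (a higher number here means that more compound is needed for the effect, a lower number that less compound is needed), compound 1 `Cc1nn(Cc2cccc(C(N)=O)c2)c(C)c1NC(=O)c1ccc(COc2ccccc2)cc1` gives 9200 nM and compound 2 `Cc1nn(Cc2cccc(C(=O)NC(C)C)c2)c(C)c1NC(=O)c1ccc(COc2ccccc2)cc1` gives 8900 nM; the step of a 1.0-fold lower number from compound 1 to compound 2 (0.01 log units; within the scatter) is the only one-place change among the measured compounds, and it lies within the scatter. Compound 3 `CNC(=O)c1cccc(Cn2nc(C)c(NC(=O)c3ccc(COc4cccc(C)c4)cc3)c2C)c1` gives 6200 nM in this assay, the lowest of the three numbers, though its gaps to compound 2 and to compound 1 are both within the scatter, so no order among the three can be claimed.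

Compound 4 `CNC(=O)c1cccc(Cn2nc(C)c(NC(=O)c3ccc(COc4ccccc4C(F)(F)F)cc3)c2C)c1` differs from compound 3 by 2-(trifluoromethyl)phenyl in place of 3-methylphenyl on an oxygen on a saturated carbon. Going by the values given here, no measured step touches the aryl group on that oxygen: the only step concerns the amide nitrogen, and compounds 1 and 2 differ from compound 3 in two places at once, so their values show only that the three numbers sit close together. With nothing in the measured steps pointing in either direction, compound 4 is expected to stay near compound 3, a step of a 1.0-fold higher number from compound 3 to compound 4 (0.02 log units; within the scatter) within the scatter. The estimate for compound 4 in this assay is 6500 nM, with a range from 2500 nM to 17000 nM.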

Compound 4, half-maximal effective concentration: 10000 nM
Compound 4: middle estimate off by 1.5-fold (0.19 log units), on the low side; low and high end bracket the measured number.
By their numbers in this assay, from the lowest: compounds 3, 2, 1 and 4 (each within the scatter of the next).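

Among the compounds shown, this is the only step at the aryl group on the oxygen on a saturated carbon: 2-(trifluoromethyl)phenyl in place of 3-methylphenyl gives a 1.6-fold higher number from compound 3 to compound 4 (0.21 log units; within the scatter). In this assay, therefore, an exchange that brings in fluorine and alters both the substituent and its ring position leaves compound 4 indistinguishable from compound 3. No measurement is at hand that bears on this result.

For the compounds shown here, the single step alters the substituent and its ring position together, so the separate contribution of each stays open; 2-methylphenyl and 3-(trifluoromethyl)phenyl would separate them. Also open, on these data alone, is whether any group other than a substituted phenyl can sit on that oxygen and keep the number in this range, such as a pyridine ring, a cyclohexyl ring or a phenyl ring carrying an amine or a carboxylic acid.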